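Fluorocyclopropyl amide on the bicyclic core: expected calcium response

The source may hold more compounds than are shown below. What is called first, only, known or untested is meant among the compounds shown, and "the series" means these compounds.

Compound 1 `CCC(=O)N1CC2CC(C1)N2`: 120%
Compound 2 `CC(C)C(=O)N1CC2CC(C1)N2`: 45%
Compound 3 `O=C(C1CC=CC1)N1CC2CC(C1)N2`: 99%

In an assay on CHO cells for agonist activity at Neuronal acetylcholine receptor; alpha3/alpha6/beta2/beta3 (Homo sapiens), read by FLIPR and calcium flux (on this read-out higher numbers stand for larger maximal responses and lower numbers for smaller maximal responses), compound 2 stands lowest of the three measured compounds; compound 3 gives 99% and compound 1 gives 120%. Compound 4 `O=C([C@@H]1C[C@@H]1F)N1CC2CC(C1)N2` is not yet measured. It differs from compound 2 by 2-fluorocyclopropyl in place of isopropyl on a carbonyl carbon. Within the data shown here, the one measured step that bears on this position is a number 75 percentage points lower from compound 1 to compound 2 (beyond the scatter), so a change on the group at the carbonyl carbon has shifted this read-out strongly. Compound 3, which carries a ring at the same place, stands far above compound 2. A move back upward is therefore expected for compound 4, a number 35 percentage points higher from compound 2 to compound 4 (beyond the scatter), though its size is uncertain. Compound 4 is estimated at 80%, within 40% to 120%.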

Compound 4, largest response reached (Emax), in percent of the reference or control that the assay uses: 120%
Compound 4: middle estimate off by 40 percentage points, on the low side; the measured number falls inside the stated range.
By their numbers in this assay, from the lowest: compound 2; then compound 3; then compounds 1 and 4 (each within the scatter of the next).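

In this assay, 2-fluorocyclopropyl in place of isopropyl on the carbonyl carbon brings a number 75 percentage points higher from compound 2 to compound 4 (beyond the scatter) and so shows that the low response of compound 2 does not extend to every group with more heavy atoms at this place. Set against ethyl, the same group brings no change at the digits printed from compound 1 to compound 4 (within the scatter) and so restores the response of compound 1 in full. Nothing measured here explains why isopropyl stands apart. The compounds shown leave open whether a plain cyclopropyl without the fluorine, or a longer chain such as butyl, would keep this response, and how the opposite stereoisomer of the 2-fluorocyclopropyl group would read.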